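Carbamate series: halogen in place of butoxycarbonyl

The source may report more compounds than this note shows. Statements on the series, on what has been measured and on what is new or still open speak of the compounds shown alone.

Measured so far:
Compound 1, `C=C1C(=O)OC[C@H]1CCOC(=O)Nc1ccc(C(=O)OCCCC)cc1`: 8940 nM
Compound 2, `C=C1C(=O)OC[C@@H]1CCOC(=O)Nc1ccc(CC)cc1`: 7580 nM
Compound 3, `C=C1C(=O)OC[C@@H]1CCOC(=O)Nc1ccc(Cl)cc1`: 10300 nM

In an ADME assay on RAW264.7 cells (Mus musculus) for cytotoxicity, read by MTT assay, with a stated time of 18 h (on this read-out higher numbers stand for lower toxicity in this test and lower numbers for higher toxicity in this test), the three compounds lie within the scatter of one another. Compound 1 gives 8940 nM; compound 3 gives 10300 nM, and compound 2 gives 7580 nM. Within the data shown here, the only step between two measured compounds that differ in one place is a 1.4-fold higher number from compound 2 to compound 3 (0.13 log units; within the scatter), and it stays within the scatter.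

Compound 4, `C=C1C(=O)OC[C@H]1CCOC(=O)Nc1ccc(Br)cc1`, has not yet been measured in this assay. It differs from compound 1 by bromo in place of butoxycarbonyl on an aromatic carbon. Nothing measured here separates a halogen from a carbon substituent at that position by more than the scatter, so no step beyond the scatter is expected: a 1.1-fold higher number from compound 1 to compound 4 (0.03 log units; within the scatter). Compound 4 is estimated at 9500 nM, with a range from 5000 nM to 18000 nM.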

Compound 4, half-maximal cytotoxic concentration: 8470 nM
Beside the measured number, compound 4's estimate is 1.1-fold (0.05 log units) above it, and the stated range covers the measured number.
By their numbers in this assay, from the lowest: compounds 2, 4, 1 and 3 (each within the scatter of the next).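

In this assay, exchanging butoxycarbonyl, with 7 heavy atoms and 2 hydrogen-bond acceptors, for bromo, with 1 heavy atom and none, gives a 1.1-fold lower number from compound 1 to compound 4 (0.02 log units; within the scatter). On this aromatic carbon, then, even this large a change in the group's atom count leaves the number within the scatter, which the earlier ethyl-to-chloro step, a swap of two small groups, could not show. Nothing measured here explains why the number holds.

From the compounds shown here alone, whether an amine or a carboxylic acid on this carbon would move the number beyond the scatter remains open. So does whether a longer chain would.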